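Lengthening the Ester Chain on a Second Core

A few compounds are considered here, and "the series" means these few. Any claim that something is new, unique, unknown or untested is made for them only; others in the source may bear on it.

Compound 1, `CCCCOC(=O)c1ccc(S(N)(=O)=O)cc1`: 2.34
Compound 2, `CCCCCOC(=O)c1ccc(S(N)(=O)=O)cc1`: 2.71
Compound 3, `CCCCOC(=O)c1cccc(S(N)(=O)=O)c1`: 2.24

These three numbers come from a physicochemical assay for lipophilicity; a higher number here means a more lipophilic compound, a lower number a more polar compound. Compound 1 and compound 2 differ by methyl in place of hydrogen on a saturated chain carbon, four bonds along the chain from an oxygen next to a carbonyl group, and that change produced a number 0.37 log units higher from compound 1 to compound 2 (beyond the scatter). Compound 3 is built from the same atoms as compound 1, joined differently; the difference between the two cores is not broken down here. In this assay compound 3 and compound 1 lie within the scatter of each other.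

Compound 4, `CCCCCOC(=O)c1cccc(S(N)(=O)=O)c1`, has not yet been measured. It differs from compound 3 by methyl in place of hydrogen on a saturated chain carbon, four bonds along the chain from an oxygen next to a carbonyl group, the same change seen between compound 1 and compound 2, in the same place. Compound 4 is therefore expected to show a number 0.37 log units higher from compound 3 to compound 4 (beyond the scatter), giving an estimated 2.61 with a likely range from 2.35 to 2.87. That expectation rests on the earlier step, a number 0.37 log units higher from compound 1 to compound 2 (beyond the scatter), applied to the value of compound 3, 2.24.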

Compound 4, partition coefficient: 2.71
Beside the measured number, compound 4's estimate is 0.10 log units below it; measured number inside the range.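

In this assay the same replacement of hydrogen by methyl gives a number 0.47 log units higher from compound 3 to compound 4 (beyond the scatter) on the second core, and it gave a number 0.37 log units higher from compound 1 to compound 2 (beyond the scatter) on the core of compound 1. Both steps are beyond the scatter and point the same way, so in this pair of cores the change carried over in direction. Two pairs cannot show that it would carry over to any further core, and nothing available explains the size of either step.

The compounds shown leave open whether a longer chain, such as hexyl, would continue the same trend on both cores. They also leave open what a carboxylic acid or an amine in place of the ester chain would give.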